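Branching the Carbamate Amine: From Diethyl to Diisopropyl

A few compounds are considered here, and "the series" means these few. Any claim that something is new, unique, unknown or untested is made for them only; others in the source may bear on it.

Compound 3 `CCN(CC)C(=O)Oc1cccc(-c2cc(-c3ccccc3)nc(N)n2)c1` gives 0.468 nM in an assay (strain Sprague-Dawley) for displacement of a labelled ligand from adenosine receptor A1 (Rattus norvegicus), read by scintillation counting, with a stated time of 1 h (a lower number here means a stronger inhibitor, a higher number a weaker inhibitor), the lowest of the three numbers measured. Compound 1 `Nc1nc(-c2ccccc2)cc(-c2cccc(OC(=O)N3CCCCC3)c2)n1` gives 1.95 nM and compound 2 `Nc1nc(-c2ccccc2)cc(-c2cccc(OC(=O)N3CCOCC3)c2)n1` gives 2.65 nM. The two measured steps that change the amine on the carbonyl carbon run a 4.2-fold lower number from compound 1 to compound 3 (0.62 log units; beyond the scatter) and a 5.7-fold lower number from compound 2 to compound 3 (0.75 log units; beyond the scatter), while a 1.4-fold higher number from compound 1 to compound 2 (0.13 log units; within the scatter). Compound 4 `CC(C)N(C(=O)Oc1cccc(-c2cc(-c3ccccc3)nc(N)n2)c1)C(C)C` differs from compound 3 in one place: diisopropylamino in place of diethylamino on a carbonyl carbon. Within the data shown here, no measured step goes from diethylamino to another acyclic amine, so the direction is uncertain; the earlier steps show only that the diethylamino group of compound 3 did better than both ring amines. A modest rise is expected, a 2.1-fold higher number from compound 3 to compound 4 (0.33 log units; beyond the scatter). Compound 4 is estimated at 1 nM, from 0.25 nM to 4 nM.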

Compound 4, inhibition constant: 0.175 nM
The estimate for compound 4 lay 5.7-fold (0.76 log units) above the measured number; the whole stated range lies above it.
By their numbers in this assay, from the lowest: compound 4; then compound 3; then compounds 1 and 2 (each within the scatter of the next).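

In this assay, among these compounds, the change gave a 2.7-fold lower number from compound 3 to compound 4 (0.43 log units; beyond the scatter) as the first measured step between two acyclic amines on this carbonyl carbon, showing that the number can fall further than it did with diethylamino. Against the ring amines, the gap grows to an 11-fold lower number from compound 1 to compound 4 (1.05 log units; beyond the scatter) and a 15-fold lower number from compound 2 to compound 4 (1.18 log units; beyond the scatter) and compound 4 holds the lowest number of the four. Nothing measured here accounts for this change.

On these data alone, whether branching or chain size goes with the lower number stays open. A straight-chain amine such as dipropylamino could separate the two.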